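The source may hold more compounds than are shown below. What is called first, only, known or untested is meant among the compounds shown, and "the series" means these compounds.

Compound 1 `CN(Cc1cccc(F)c1)C(=O)CCCNC(=O)c1ccc(S(C)(=O)=O)c([N+](=O)[O-])c1` carries the shared core, a nitro- and methylsulfonyl-bearing aromatic amide, linked through a short saturated chain to a second amide. In an assay on isolated protein for inhibition of vitamin D3 receptor (Homo sapiens), read by fluorescence polarization (on this read-out lower numbers stand for stronger inhibition and higher numbers for weaker inhibition), compound 1 gives only a limit of the assay, > 60000 nM, and no number. Two related compounds are known. Compound 2 `CN(CC(=O)N1CCN(c2ccc(F)cc2)CC1)C(=O)c1ccc(S(C)(=O)=O)c([N+](=O)[O-])c1` also gives only a limit, > 60000 nM, in this assay. Compound 3 `CN(CC(=O)N1CCN(c2ccccc2)CC1)C(=O)c1ccc(S(C)(=O)=O)c([N+](=O)[O-])c1` likewise gives only a limit, > 60000 nM. Going by the values given here, the one step that can be drawn between them, a step that the two limits leave unreadable from compound 2 to compound 3, is therefore unreadable in size, since both ends sit at the same limit (the limit of > 60000 nM in this assay, at which 3 of the 3 values shown sit).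

Compound 4 `CS(=O)(=O)c1ccc(C(=O)NCCCC(=O)N2CCCCC2)cc1[N+](=O)[O-]` is not yet measured. It differs from compound 1 in one place: piperidin-1-yl in place of (3-fluorobenzyl)(methyl)amino on a carbonyl carbon. Among the compounds with values here, no measured step bears directly on this exchange; the only measured step, from compound 2 to compound 3, lies between two limits and says nothing about how large a change at this position can be. Every value shown sits at the limit, so the expectation for compound 4 is that it will also fall at or beyond that limit, with a step from compound 1 of a step that the limit leaves unreadable from compound 1 to compound 4 expected. Compound 4 is estimated at 100000 nM, with a range from 30000 nM to 400000 nM.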

Compound 4, half-maximal inhibitory concentration: > 60000 nM
Compound 4: no number, only a limit; the forecaster's own chance of this, stated with the estimate: 85%; the middle value is on the limit's open side.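

No step can be read between compound 1 and compound 4, where piperidin-1-yl replaces (3-fluorobenzyl)(methyl)amino, because both stand at the same limit and neither gives a number: the limit of > 60000 nM in this assay, at which 4 of the 4 values shown sit.

The compounds shown leave open whether any compound of this kind gives a readable number in this assay, and so which groups affect inhibition.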